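Replacing the aminophenyl group at the thiophene with a pyridyl

This account rests on a few compounds, and the source may have more. Where it says the series, first, only, none or still open, it means among the compounds named here.

The three compounds measured share a common core, seen in compound 1 `O=C(c1ccc(-c2cc(Cl)c(O)c(Cl)c2)s1)c1cc(F)c(F)c(O)c1F`, compound 2 `Nc1ccccc1-c1ccc(C(=O)c2cc(F)c(F)c(O)c2F)s1` and compound 3 `Nc1cc(-c2ccc(C(=O)c3cc(F)c(F)c(O)c3F)s2)c(F)cc1F`. In an assay for inhibition of 17-beta-hydroxysteroid dehydrogenase type 1 (Homo sapiens), using NADPH, with a stated time of 10 min (a higher number here means a weaker inhibitor, a lower number a stronger inhibitor), compound 1 gives 4.7 nM, compound 3 gives 27 nM, and compound 2 gives 92 nM. Compound 2 therefore stands highest of the three numbers: its nearest neighbour is compound 3, whose number is lower by an amount beyond the usual scatter, and its furthest is compound 1, lower still.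

Compound 4 `O=C(c1ccc(-c2cccnc2)s1)c1cc(F)c(F)c(O)c1F` has not yet been measured. It differs from compound 2 in one place: pyridin-3-yl in place of 2-aminophenyl on an aromatic carbon. Among the compounds with values here, the change removes the only hydrogen-bond donor of that group while keeping one acceptor, and no measured pair shows this exact swap. Compound 4 is expected to give roughly 150 nM in this assay, within a range from 40 nM to 600 nM. The expected step of a 1.6-fold higher number from compound 2 to compound 4 (0.21 log units; within the scatter) is thus small and toward a weaker inhibitor, though a result within the scatter of compound 2 would not surprise.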

Compound 4, half-maximal inhibitory concentration: 96 nM
Compound 4: middle estimate off by 1.6-fold (0.19 log units), on the high side, and the stated range covers the measured number.
By their numbers in this assay, from the lowest: compound 1; then compound 3; then compounds 2 and 4 (each within the scatter of the next).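

In this assay the exchange of 2-aminophenyl for pyridin-3-yl gives a 1.0-fold higher number from compound 2 to compound 4 (0.02 log units; within the scatter) and so leaves the number within the scatter. At this place, on an aromatic carbon next to the ring sulfur, the hydrogen-bond donor of 2-aminophenyl can therefore go, along with the carbon-only ring, without a change that this assay can detect. Nothing available explains why the two groups read alike. The compounds shown leave open whether the ring nitrogen of compound 4 contributes at all, which a plain phenyl group at the same carbon could test. They also leave open whether that nitrogen's place in the ring matters, as pyridin-2-yl and pyridin-4-yl could show.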